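This account rests on a few compounds, and the source may have more. Where it says the series, first, only, none or still open, it means among the compounds named here.

Of the compounds shown here, two of the shared core have been measured in a functional assay on LoVo cells (Homo sapiens) for cytotoxicity, read by MTT assay, with a stated time of 72 h; on this read-out higher numbers stand for weaker inhibition and lower numbers for stronger inhibition. Compound 1 `O=C(Nc1ccc(-n2ncc3c(Cl)cccc32)cc1)Nc1ccc(Cl)c(C(F)(F)F)c1` gives 3600 nM in this assay, the upper of the two numbers, but its gap to compound 2 `O=C(Nc1ccc(-n2ncc3c(C(F)(F)F)cccc32)cc1)Nc1ccc(C(F)(F)F)cc1`, which gives 2200 nM, lies within the scatter, so nothing can be read into the order. Compound 3 `O=C(Nc1ccc(-n2ncc3cnccc32)cc1)Nc1ccc(Cl)c(C(F)(F)F)c1` has not been measured; it arises from compound 1 by a group of 9 heavy atoms (6 carbon, 3 nitrogen; one five-membered aromatic ring with 2 hetero atoms, one six-membered aromatic ring with 1 hetero atom) in place of a group of 10 heavy atoms (7 carbon, 2 nitrogen, 1 chlorine; one five-membered aromatic ring with 2 hetero atoms, one six-membered aromatic ring of carbon only), on an aromatic carbon. Going by the values given here, no measured pair shows a change of this kind, so no direction can be taken from the numbers. The step is expected to stay within the scatter, with a slight lean to a higher number: a 1.3-fold higher number from compound 1 to compound 3 (0.10 log units; within the scatter). In this assay compound 3 is expected to give about 4500 nM, with a range from 1500 nM to 14000 nM.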

Compound 3, half-maximal inhibitory concentration: 8000 nM
Compound 3: middle estimate off by 1.8-fold (0.25 log units), on the low side; measured number inside the range.
By their numbers in this assay, from the lowest: compounds 2 and 1 (each within the scatter of the next); then compound 3.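

In this assay, replacing the 4-chloro-1H-indazol-1-yl group with the group carrying a nitrogen in its six-membered aromatic ring gives a 2.2-fold higher number from compound 1 to compound 3 (0.35 log units; beyond the scatter), a modest step but beyond the scatter. Going by these compounds alone, this is the first readable step, and it shows that the group on this aromatic carbon, para to a large group, is not indifferent to this change. No measured data explain the step.

The step removes the chlorine and adds the ring nitrogen together, and the compounds shown do not separate these two changes. Also open, on these data alone, is how an amine or a methoxy group in place of the chlorine would read, on the ring of carbon only.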